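Adding trifluoromethyl to compound 3

The source may hold more compounds than are shown below. What is called first, only, known or untested is meant among the compounds shown, and "the series" means these compounds.

In a functional assay on K562 cells (Homo sapiens) for cytotoxicity, read by flow cytometry, with a stated time of 72 h (on this read-out higher numbers stand for weaker inhibition and lower numbers for stronger inhibition), compound 3 `CC(C)=Cc1nc(Nc2ccccc2)c2cc([N+](=O)[O-])ccc2n1` reports only a limit, > 125000 nM. Compound 4 `CC(C)=Cc1nc(Nc2cccc(C(F)(F)F)c2)c2cc([N+](=O)[O-])ccc2n1` carries trifluoromethyl in place of hydrogen on an aromatic carbon, meta to a large group: trifluoromethyl in place of hydrogen on an aromatic carbon. Compound 1 `Cc1ccc(S(=O)(=O)Cc2nc(Nc3cccc(C(F)(F)F)c3)c3ccccc3n2)cc1`, which bears trifluoromethyl on a different core, also reports only a limit, > 25000 nM. Its bromo partner is compound 2 `Cc1ccc(S(=O)(=O)Cc2nc(Nc3cccc(Br)c3)c3ccccc3n2)cc1`. Compound 2 reports a limit too, > 15000 nM. Among the compounds with values here, the one measured step is a step that the two limits leave unreadable from compound 1 to compound 2, so it offers no size to carry over. Since compound 1 shows only the limit > 25000 nM, strong inhibition is not expected from this change. The expected step is modest and towards stronger inhibition, estimated as an at least 2.0-fold lower number from compound 3 to compound 4 (0.31 log units; beyond the scatter). For compound 4 the estimate is 60000 nM, with an expected range of 15000 nM to 200000 nM.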

Compound 4, half-maximal inhibitory concentration: > 125000 nM
Compound 4 was reported as a limit; the forecaster's own chance of this, stated with the estimate: 65%; middle value at least 2.0-fold (0.31 log units) from the limit.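

Within the data shown here, compound 3 and compound 4 both stand only as limits in this assay, so no step between them can be read. The compounds shown leave open whether trifluoromethyl in place of hydrogen changes inhibition at all.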